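Swapping Methyl for Chloro on Compound 1

This account rests on a few compounds, and the source may have more. Where it says the series, first, only, none or still open, it means among the compounds named here.

Among the measured compounds shown here, in a functional assay on HCT-116 cells (Homo sapiens) for antiproliferative activity, read by MTT assay, with a stated time of 48 h (on this read-out higher numbers stand for weaker inhibition and lower numbers for stronger inhibition), compound 1 `Cc1ccc2nc(Nc3nc(Nc4ccc(S(N)(=O)=O)cc4)ncc3C)sc2c1` gives 3870 nM, the highest of the two numbers measured so far; the nearest compound, compound 2 `Cc1ccc2nc(Nc3ccnc(Nc4ccc(S(N)(=O)=O)cc4)n3)sc2c1`, gives 900 nM, a step of a 4.3-fold lower number from compound 1 to compound 2 (0.63 log units; beyond the scatter). Compound 3 `Cc1cnc(Nc2ccc(S(N)(=O)=O)cc2)nc1Nc1nc2ccc(Cl)cc2s1` differs from compound 1 by chloro in place of methyl on an aromatic carbon. For the measured compounds named here, the one measured step removes a methyl from another part of the shared core, so no step bears directly on this exchange, and the data give no ground for expecting movement beyond the scatter. Compound 3 is therefore expected to give 3000 nM, within a range from 1000 nM to 9000 nM, a step of a 1.3-fold lower number from compound 1 to compound 3 (0.11 log units; within the scatter) that is expected to stay within the scatter.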

Compound 3, half-maximal inhibitory concentration: 2520 nM
Compound 3: middle estimate off by 1.2-fold (0.08 log units), on the high side; measured number inside the range.
By their numbers in this assay, from the lowest: compound 2; then compounds 3 and 1 (each within the scatter of the next).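

In this assay, chloro in place of methyl on this aromatic carbon gives a 1.5-fold lower number from compound 1 to compound 3 (0.19 log units; within the scatter), so this read-out does not separate the two groups at this position. Among the compounds shown here, this is the first look at this position, as the earlier step concerned a methyl on another part of the shared core. Nothing measured here offers an explanation for this result.

Going by these compounds, whether an amine, a methoxy group or a carboxylic acid on this aromatic carbon would move the number beyond the scatter stays open. So does whether the same exchange would read alike on compound 2, which lacks that other methyl.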